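This account rests on a few compounds, and the source may have more. Where it says the series, first, only, none or still open, it means among the compounds named here.

Working notes on the series, all read in an ADME assay on L6 cells (Rattus norvegicus) for cytotoxicity, read by resazurin assay, with a stated time of 72 h; a higher number here means a weaker inhibitor, a lower number a stronger inhibitor. Compound 1 `OC(c1ccc(Cl)cc1)(c1ccc(Br)cc1)c1cncnc1` gives 58700 nM, compound 2 `OC(c1ccc(Cl)cc1)(c1cccnc1)c1cccc(F)c1` gives 66000 nM, and compound 3 `OC(c1ccc(Cl)cc1)(c1ccc(Br)cc1)c1cccnc1` gives 57000 nM. Compound 3 therefore lies within the scatter of both compound 1 and compound 2.

The next compound is compound 4 `OC(c1ccc(Cl)cc1)(c1cccnc1)c1cccs1`, which carries thiophen-2-yl in place of the 4-bromophenyl of compound 3: thiophen-2-yl in place of 4-bromophenyl on a saturated chain carbon bound to two aromatic carbons and an oxygen on a saturated carbon. For the measured compounds named here, the closest precedent is the one measured exchange involving that same 4-bromophenyl, a step of a 1.2-fold lower number from compound 2 to compound 3 (0.06 log units; within the scatter). The exchange of the other aromatic group gave a step of a 1.0-fold lower number from compound 1 to compound 3 (0.01 log units; within the scatter). Both steps stay within the scatter, but neither involves a thiophen-2-yl group, so the precedent is indirect.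

No step beyond the scatter is therefore expected in this assay, and no direction can be favoured with confidence. The expected step is a 1.1-fold higher number from compound 3 to compound 4 (0.06 log units; within the scatter). For compound 4 the estimated value is 65000 nM, with an expected range of 30000 nM to 130000 nM.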

Compound 4, half-maximal inhibitory concentration: 67700 nM
Beside the measured number, compound 4's estimate is 1.0-fold (0.02 log units) below it; the measured number falls inside the stated range.
By their numbers in this assay, from the lowest: compounds 3, 1, 2 and 4 (each within the scatter of the next).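

In this assay, the place on a saturated chain carbon bound to two aromatic carbons and an oxygen on a saturated carbon now also takes a five-membered aromatic ring with 1 hetero atom without a step beyond the scatter: thiophen-2-yl in place of 4-bromophenyl gives a 1.2-fold higher number from compound 3 to compound 4 (0.07 log units; within the scatter), and thiophen-2-yl in place of 3-fluorophenyl gives a 1.0-fold higher number from compound 2 to compound 4 (0.01 log units; within the scatter). Across compounds 2, 3 and 4, the read-out therefore does not separate these three aromatic groups at this place, although ring size and heavy-atom count differ between thiophen-2-yl and 4-bromophenyl. No measured evidence bears on why these values stay within the scatter.

Going by these compounds, it remains open whether a group of another kind at this place, such as an amine, a carboxylic acid or a longer chain, would give a step beyond the scatter.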